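Replacing 1H-pyrazol-5-yl with thiophen-2-yl in compound 2

The compounds below may be only part of what the source reports. "The series", "measured", "known", "first", "only" and "open" are said of these compounds alone.

Measured in a functional assay on A-375 cells (Homo sapiens) for activation, with a stated time of 3 days; a lower number here means that less compound is needed, a higher number that more compound is needed for the effect:
compound 1 `O=C(Nc1ccc(-c2cscn2)cc1)C1CCCN(Cc2ccc(F)c(F)c2)C1`: 1240 nM
compound 2 `O=C(Nc1ccc(-c2ccn[nH]2)cc1)C1CCCN(Cc2ccc(F)c(F)c2)C1`: 580 nM

Of these two compounds, compound 2 has the lower number in this assay, at 580 nM. Compound 3 `O=C(Nc1ccc(-c2cccs2)cc1)C1CCCN(Cc2ccc(F)c(F)c2)C1` keeps the rest of compound 2 and changes one group: thiophen-2-yl in place of 1H-pyrazol-5-yl on an aromatic carbon. It carries thiophen-2-yl in place of 1H-pyrazol-5-yl on an aromatic carbon, para to a large group. Among the compounds with values here, one measured step bears on this exchange: a 2.1-fold lower number from compound 1 to compound 2 (0.33 log units; beyond the scatter), a modest step just beyond the scatter, which put 1H-pyrazol-5-yl in place of 1,3-thiazol-4-yl at the same place. Within the data shown here, with only that step as a guide, a similarly modest move towards a higher number is expected in this assay, and the support for it is thin. The expected step is a 1.9-fold higher number from compound 2 to compound 3 (0.28 log units; within the scatter). For compound 3 the estimate is 1100 nM, with an expected range of 480 nM to 2500 nM.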

Compound 3, half-maximal effective concentration: 530 nM
Estimate against measurement, compound 3: 2.1-fold (0.32 log units) above, within the range that was stated.
By their numbers in this assay, from the lowest: compounds 3 and 2 (each within the scatter of the next); then compound 1.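

In this assay the exchange gives a 1.1-fold lower number from compound 2 to compound 3 (0.04 log units; within the scatter) even though 1H-pyrazol-5-yl carries a hydrogen-bond donor and thiophen-2-yl carries none, so among these compounds that donor is not required at this place on the ring. The same thiophen-2-yl gives a 2.3-fold lower number from compound 1 to compound 3 (0.37 log units; beyond the scatter) when it takes the place of 1,3-thiazol-4-yl, which leaves compound 1 apart from both compound 2 and compound 3, with two different five-membered rings now on the side of the lower number. No measurement at hand accounts for that separation.

The compounds shown leave open whether a six-membered ring such as pyridine, or a simple amine or a carboxylic acid, would be tolerated at this place. They also leave open whether the match between 1H-pyrazol-5-yl and thiophen-2-yl would hold if the rest of the molecule were altered.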